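Swapping Fluorine for Chlorine on a Benzyl Ether

The compounds below may be only part of what the source reports. "The series", "measured", "known", "first", "only" and "open" are said of these compounds alone.

Of the compounds shown here, three of one series have been tested in an ADME assay on HepG2 2.2.15 cells (Homo sapiens) for cytotoxicity; a lower number here means that less compound is tolerated, a higher number that more compound is tolerated. Compound 1 `CC(C)(C)[Si](CCc1c(OCc2c(F)cccc2F)nc2ccc(Cl)cc2c1-c1ccccc1Cl)(c1ccccc1)c1ccccc1` reaches only a limit in this assay, > 1860000 nM. Compound 2 `CC(C)(C)[Si](CCc1c(OCc2c(Cl)cccc2Cl)nc2ccc(Cl)cc2c1-c1ccccc1Cl)(c1ccccc1)c1ccccc1` differs from compound 1 by 2,6-dichlorophenyl in place of 2,6-difluorophenyl on a saturated chain carbon bound to an oxygen on an aromatic ring. Compound 2 likewise gives only a limit in this assay, > 1020000 nM. Between them lies a step that the two limits leave unreadable from compound 1 to compound 2, which follows from the limit of > 1020000 nM in this assay, at which 1 of the 3 values shown sits, and from the limit of > 1860000 nM in this assay, at which 1 of the 3 values shown sits. Compound 3 `OCCc1c(OCc2c(F)cccc2F)nc2ccc(Cl)cc2c1-c1ccccc1Cl` is built on a different core; how the core of compound 3 differs from that of compound 1 is not broken down here. In this assay, among the compounds with values here, compound 3 gives 109000 nM, the only number among the three. Compound 4 `OCCc1c(OCc2c(Cl)cccc2Cl)nc2ccc(Cl)cc2c1-c1ccccc1Cl` stands to compound 3 as compound 2 stands to compound 1: 2,6-dichlorophenyl in place of 2,6-difluorophenyl on a saturated chain carbon bound to an oxygen on an aromatic ring. The same kind of change is thus repeated on the second core. The measured pair leaves the size of this step unreadable, so the expectation for compound 4 rests on compound 3 alone, whose value in this assay is 109000 nM. The expected step is a 1.1-fold lower number from compound 3 to compound 4 (0.06 log units; within the scatter), small in either direction. Compound 4 is therefore estimated at 95000 nM, between 35000 nM and 260000 nM.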

Compound 4, half-maximal cytotoxic concentration: 38500 nM
The estimate for compound 4 lay 2.5-fold (0.39 log units) above the measured number; measured number inside the range.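

On the core of compound 3, in this assay, replacing 2,6-difluorobenzyl with 2,6-dichlorobenzyl gives a 2.8-fold lower number from compound 3 to compound 4 (0.45 log units; beyond the scatter) and thus a step that can be read on this core. Within the data shown here, the same change on the core of compound 1 cannot be read, since compound 1 and compound 2 each give only a limit, so no second measured step stands beside this one. The result therefore shows what the change does on one core, but not whether that step carries over to the other, and nothing shown accounts for its size.

As far as these compounds go, it remains open whether the lower number follows the chlorine atoms specifically, which a plain benzyl or a 2,6-dimethylbenzyl ether on the core of compound 3 would help to settle. From the compounds shown here alone, it is also open whether the step would hold with a carboxylic acid or an amine at the end of the chain that carries the hydroxyl group in compound 3 and compound 4.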